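The source may report more compounds than this note shows. Statements on the series, on what has been measured and on what is new or still open speak of the compounds shown alone.

In an assay for inhibition of serine/threonine-protein kinase Sgk1 (Homo sapiens), with stated times of 30 min and 60 min, in the presence of a further agent that is not named here (a lower number here means a stronger inhibitor, a higher number a weaker inhibitor), compound 1 `O=C(N[C@@H]1CCNC1)c1cc(-c2ccc(NS(=O)(=O)c3cccc(Cl)c3Cl)cc2)nc2[nH]ncc12` gives < 1 nM, which is a limit of the assay rather than a number (the limit of < 1 nM in this assay, at which 1 of the 3 values shown sits). Compound 2 `CN1CCC(NC(=O)c2cc(-c3ccc(NS(=O)(=O)c4cccc(Cl)c4Cl)cc3)nc3[nH]ncc23)C1` gives 21 nM. Compound 3 `CCNC(=O)c1cc(-c2ccc(NS(=O)(=O)c3cccc(Cl)c3Cl)cc2)nc2[nH]ncc12` gives < 1920 nM, again only a limit and not a number (the limit of < 1920 nM in this assay, at which 1 of the 3 values shown sits). Compound 3 therefore stands at a limit, with no measured number of its own among the three values. Compound 4 `CC(C)NC(=O)c1cc(-c2ccc(NS(=O)(=O)c3cccc(Cl)c3Cl)cc2)nc2[nH]ncc12` differs from compound 3 by methyl in place of hydrogen on a saturated chain carbon bound to an amide-type nitrogen and a saturated chain carbon. Of the measured steps, an at least 21-fold higher number from compound 1 to compound 2 (1.32 log units; beyond the scatter) concerns a methyl entering on a ring nitrogen, not on a chain carbon, while a step that the two limits leave unreadable from compound 1 to compound 3 and a step that the limit leaves unreadable from compound 2 to compound 3 cannot be read. For the measured compounds named here, no measured step speaks directly to this change, and no shift beyond the scatter is expected in this assay. Compound 4 is estimated at 600 nM, within 80 nM to 1900 nM. The expected step is a step that the limit leaves unreadable from compound 3 to compound 4.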

Compound 4, half-maximal inhibitory concentration: 17600 nM
Beside the measured number, compound 4's estimate is 29-fold (1.47 log units) below it; the measured number lies above the stated range.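

In this assay, methyl in place of hydrogen on a saturated chain carbon bound to an amide-type nitrogen proves no silent change, giving an at least 9.1-fold higher number from compound 3 to compound 4 (0.96 log units; beyond the scatter). This step rests on a limit for compound 3: the limit of < 1920 nM in this assay, at which 1 of the 4 values shown sits.

Isopropyl in place of the two pyrrolidine groups gives an 840-fold higher number from compound 2 to compound 4 (2.92 log units; beyond the scatter) and an at least 17000-fold higher number from compound 1 to compound 4 (4.24 log units; beyond the scatter), so the earlier gap between the ring amines and the open-chain groups now has a readable size.

The compounds shown leave open whether the ring or its nitrogen matters more, since cyclopentyl, a ring without an amine, does not appear among them. On these data alone, how 2-aminoethyl, an open-chain amine, would stand on this amide-type nitrogen also remains open.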